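Removing the phenyl from compound 2: working notes

This account rests on a few compounds, and the source may have more. Where it says the series, first, only, none or still open, it means among the compounds named here.

In a functional assay on MCF7 cells (Homo sapiens) for antiproliferative activity, read by MTT assay, with a stated time of 48 h (on this read-out lower numbers stand for stronger inhibition and higher numbers for weaker inhibition), compound 1 (`COc1cc(/C=C/C(C)=O)ccc1OCc1cn(-c2ccccc2CO)nn1`) gives 65800 nM and compound 2 (`COc1cc(/C=C/C(C)=O)ccc1OCc1cn(-c2ccc(-c3ccccc3)cc2)nn1`) gives 65400 nM so compound 2 stands level with compound 1, within the scatter. Compound 3 (`COc1cc(/C=C/C(C)=O)ccc1OCc1cn(-c2ccccc2)nn1`) has hydrogen in place of phenyl on an aromatic carbon, para to a large group, and hydrogen in place of phenyl on an aromatic carbon is the full change. Among the measured compounds shown here, the two measured compounds carry different groups on that ring yet give values within the scatter of each other, which is the only guide available. No step beyond the scatter is expected, the estimated change being a 1.1-fold lower number from compound 2 to compound 3 (0.04 log units; within the scatter) in this assay on this limited evidence. The estimate for compound 3 is 60000 nM with an expected range of 28000 nM to 125000 nM (estimated).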

Compound 3, half-maximal inhibitory concentration: > 100000 nM
Compound 3: only a limit was reported; the forecaster's own chance of this, stated with the estimate: 15%; at least 1.6-fold (0.22 log units) between middle value and limit.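

In this assay compound 3 gives > 100000 nM, which is a limit of the assay and not a number. Hydrogen in place of phenyl gives an at least 1.5-fold higher number from compound 2 to compound 3 (0.18 log units; that floor lies within the scatter), and hydrogen in place of hydroxymethyl gives an at least 1.5-fold higher number from compound 1 to compound 3 (0.18 log units; that floor lies within the scatter). Unlike the earlier pair, which stood level, this result hints that a group on this ring may count, though neither floor clears the scatter. From the compounds shown here alone, how far the true value of compound 3 lies past the limit stays open, as does what an amine or a carboxylic acid would give on this ring.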